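Benzimidazole terphenyls: dimethoxyphenyl-to-phenyl step carried over

The source may report more compounds than this note shows. Statements on the series, on what has been measured and on what is new or still open speak of the compounds shown alone.

Three members of the series have numbers in a functional assay on A2780 cells (Homo sapiens) for inhibition, read by sulforhodamine B assay; on this read-out lower numbers stand for stronger inhibition of growth and higher numbers for weaker inhibition of growth. Compound 1 `COc1ccc(-c2ccc(-c3ccc(-c4nc5cc(C)ccc5[nH]4)cc3)cc2)cc1OC` gives 2130 nM. Compound 3 `COc1ccc(-c2ccc(-c3ccc(-c4nc5c(O)cccc5[nH]4)cc3)cc2)cc1OC` gives 2710 nM, and compound 2 `Oc1cccc2[nH]c(-c3ccc(-c4ccc(-c5ccccc5)cc4)cc3)nc12` gives 41000 nM. The cores of compound 1 and compound 3 differ by 5-methyl-1H-benzimidazol-2-yl in place of 4-hydroxy-1H-benzimidazol-2-yl on an aromatic carbon, a change that shows a 1.3-fold higher number from compound 1 to compound 3 (0.10 log units; within the scatter). Within the core of compound 3, the change phenyl in place of 3,4-dimethoxyphenyl on an aromatic carbon shows a 15-fold higher number from compound 3 to compound 2 (1.18 log units; beyond the scatter).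

Compound 4 `Cc1ccc2[nH]c(-c3ccc(-c4ccc(-c5ccccc5)cc4)cc3)nc2c1` is not yet measured in this assay. It carries the change phenyl in place of 3,4-dimethoxyphenyl on an aromatic carbon on the core of compound 1; the place is worded the same as for the pair of compound 3 and compound 2, so this is the same change made once more. Within the data shown here, for compound 4 a step of a 15-fold higher number from compound 1 to compound 4 (1.18 log units; beyond the scatter) is expected, resting on the single earlier instance a 15-fold higher number from compound 3 to compound 2 (1.18 log units; beyond the scatter) and on compound 1 at 2130 nM. The estimate for compound 4 in this assay is 32000 nM, expected between 12000 nM and 85000 nM.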

Compound 4, concentration for 50% growth inhibition: 41200 nM
Estimate against measurement, compound 4: 1.3-fold (0.11 log units) below; the range from low to high includes it.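

In this assay phenyl in place of 3,4-dimethoxyphenyl gives a 19-fold higher number from compound 1 to compound 4 (1.29 log units; beyond the scatter) on the core of compound 1, so the large step carries over to a second core with its size kept. This rests on two cores only, one with 5-methyl-1H-benzimidazol-2-yl and one with 4-hydroxy-1H-benzimidazol-2-yl, and it does not show which of the two methoxy groups matters or how the step would run on any other core. The two instances side by side: the same change on two cores in this assay, a 15-fold higher number (1.18 log units; beyond the scatter) from compound 3 to compound 2 and a 19-fold higher number (1.29 log units; beyond the scatter) from compound 1 to compound 4, 1.3-fold (0.11 log units) apart, within the scatter of two such steps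

The compounds shown leave open whether a single methoxy, an amine or a carboxylic acid on that terminal ring would keep the lower numbers. Also open, from the compounds shown here alone, is how the step behaves with a fluoro group or a longer chain in place of the methyl or hydroxy of the core.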